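A few compounds are considered here, and "the series" means these few. Any claim that something is new, unique, unknown or untested is made for them only; others in the source may bear on it.

Compound 1 `CCCc1csc(CN[C@@H]2C[C@H]3C[C@@H]([C@H]2C)C3(C)C)c1`: 12500 nM
Compound 2 `C[C@H]1[C@H](NCc2cc(C3CC3)cs2)C[C@H]2C[C@@H]1C2(C)C`: 25000 nM
Compound 3 `Cc1csc(CN[C@@H]2C[C@H]3C[C@@H]([C@H]2C)C3(C)C)c1`: 12500 nM

Within the data shown here, in an ADME assay on MDCK cells (Canis lupus familiaris) for cytotoxicity, read by microscopy, with a stated time of 48 h (on this read-out higher numbers stand for lower toxicity in this test and lower numbers for higher toxicity in this test), compound 3 gives 12500 nM, level with compound 1 at the digits reported, the two together the lowest of the three numbers; the only other step, a 2.0-fold lower number from compound 2 to compound 3 (0.30 log units; within the scatter), stays within the scatter. Compound 4 `C=C(C)c1csc(CN[C@@H]2C[C@H]3C[C@@H]([C@H]2C)C3(C)C)c1` differs from compound 3 by 1-methylethenyl in place of methyl on an aromatic carbon. Among the measured compounds shown here, the steps that bear on this change at the same ring position are no change at the digits printed from compound 1 to compound 3 (within the scatter) and a 2.0-fold lower number from compound 2 to compound 3 (0.30 log units; within the scatter), neither of which leaves the scatter, so no shift beyond the scatter is expected in this assay for compound 4, which amounts to no change at the digits printed from compound 3 to compound 4 (within the scatter). Compound 4 is therefore estimated at 12500 nM, with a range from 6250 nM to 25000 nM.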

Compound 4, minimum cytotoxic concentration: 25000 nM
Estimate against measurement, compound 4: 2.0-fold (0.30 log units) below, within the range that was stated.
By their numbers in this assay, from the lowest: compounds 1, 3, 2 and 4 (each within the scatter of the next).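

In this assay, 1-methylethenyl on this aromatic carbon, two ring bonds from the ring sulfur, brings a double bond outside aromatic rings into the series, and each of its steps stays within the scatter: a 2.0-fold higher number from compound 3 to compound 4 (0.30 log units; within the scatter) and no change at the digits printed from compound 2 to compound 4 (within the scatter) and a 2.0-fold higher number from compound 1 to compound 4 (0.30 log units; within the scatter). Across the four compounds, then, methyl, propyl, cyclopropyl and 1-methylethenyl at this position are not told apart by this read-out. Nothing available explains this result. Going by these compounds, whether an amine, a carboxylic acid or a longer chain here would give a step beyond the scatter remains open.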